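The compounds below may be only part of what the source reports. "The series", "measured", "known", "first", "only" and "open" are said of these compounds alone.

Compound 1, `COc1ccc(OC)c(/C=C/c2nnc(Nc3ccc(Cl)cc3)o2)c1`, in a functional assay on NCI-H522 cells (Homo sapiens) for antiproliferative activity, read by sulforhodamine B assay, with a stated time of 48 h (a higher number here means a weaker inhibitor of growth, a lower number a stronger inhibitor of growth), gives 83700 nM.
Compound 2, `COc1ccc(OC)c(/C=C/C(=O)N/N=C/c2ccc(Cl)cc2)c1`, in this assay gives 382 nM.

Of these two, compound 2 has the lower number, and its gap to compound 1 lies far beyond the scatter, so compound 2 is the stronger growth inhibitor of the pair. The two differ in many places at once, so the numbers alone cannot say which part of the structure carries that difference. Compound 3, `COc1ccc(OC)c(/C=C/C(=O)N/N=C/c2ccccc2)c1`, has not yet been measured. It keeps the whole of compound 2 except for one change: hydrogen in place of chloro on an aromatic carbon. Among the measured compounds shown here, no measured pair here shows what this single change does, so the expectation rests on compound 2 alone. A small loss of growth inhibition is expected, a 2.1-fold higher number from compound 2 to compound 3 (0.32 log units; beyond the scatter), likely within or only just beyond the scatter. Compound 3 is therefore expected to give about 800 nM in this assay, within 250 nM to 3000 nM.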

Compound 3, concentration for total growth inhibition: 41700 nM
Compound 3: the middle estimate sits 52-fold (1.72 log units) below what was measured; the whole stated range lies below it.
By their numbers in this assay, from the lowest: compound 2; then compounds 3 and 1 (each within the scatter of the next).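

In this assay the swap of chloro for hydrogen, on the ring carbon para to a large group, gives a 110-fold higher number from compound 2 to compound 3 (2.04 log units; beyond the scatter) and so marks this position as one where a single atom has a large effect on growth inhibition. The earlier pair differed in many places and could not single out any one part, whereas this step ties a large change to the move from 4-chlorophenyl to phenyl alone. No measurement on hand explains why this one change matters so much.

The compounds shown leave open whether chlorine itself is needed or whether another group at this position, such as bromo, methoxy or an amine, would serve as well. They also leave open whether the same change would have a similar effect on a different core.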